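The source may hold more compounds than are shown below. What is called first, only, known or untested is meant among the compounds shown, and "the series" means these compounds.

Of the compounds shown here, two have so far been measured in an assay on isolated protein for inhibition of Amine oxidase [flavin-containing] B (Homo sapiens), read by fluorescence; on this read-out lower numbers stand for stronger inhibition and higher numbers for weaker inhibition. Compound 1, with the structure `CCC(C)NC(=O)c1cc2cc(Br)cc(Br)c2oc1=O`, gives 45400 nM in this assay. Compound 2, with the structure `O=C(Sc1ccc(Br)cc1)c1cc2ccccc2oc1=O`, gives 6500 nM in this assay. Within the data shown here, of the two numbers, the one for compound 2 is the lower, and its gap to the higher number of compound 1 lies beyond the usual scatter of repeated measurements. The two compounds differ from each other in more than one place, so the gap cannot be tied to any single change.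

Compound 3, with the structure `O=C(SCc1ccco1)c1cc2ccccc2oc1=O`, keeps the core of compound 2 and changes a single group: (furan-2-yl)methyl in place of 4-bromophenyl on a sulfur. Among the measured compounds shown here, no pair of measured compounds shows an exchange of this kind, so there is no measured step to lean on, and the expectation rests only on the fact that compound 2 sets the starting point. The step from compound 2 to compound 3 is expected to be a 1.8-fold higher number from compound 2 to compound 3 (0.27 log units; within the scatter), a mild weakening that could still fall within the scatter. For compound 3 the estimate in this assay is 12000 nM, with a likely range from 3000 nM to 50000 nM.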

Compound 3, half-maximal inhibitory concentration: 210 nM
Estimate against measurement, compound 3: 57-fold (1.76 log units) above; the measured number lies below the stated range.
By their numbers in this assay, from the lowest: compound 3; then compound 2; then compound 1.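

In this assay, the exchange that removes 4-bromophenyl and brings in (furan-2-yl)methyl, on a sulfur whose other neighbour is the carbonyl carbon, gives a 31-fold lower number from compound 2 to compound 3 (1.49 log units; beyond the scatter) and so shows that a single exchange at this position can move the number well beyond the usual scatter. The gap between compound 1 and compound 2 could not be tied to any one change, whereas this step ties a large difference to one place. The exchange alters several things at once, replacing a six-membered aromatic ring of carbon only with a five-membered aromatic ring with 1 hetero atom and adding a hydrogen-bond acceptor, and no measurement at hand explains the size of the step.

The compounds shown leave open whether the ring, its oxygen or the carbon that links the ring to the sulfur carries the difference, which a benzyl group or a (thiophen-2-yl)methyl group on the same sulfur would help to separate. They also leave open whether (furan-2-yl)methyl has a similar effect when an amide nitrogen takes the place of the sulfur.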